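This account rests on a few compounds, and the source may have more. Where it says the series, first, only, none or still open, it means among the compounds named here.

Working notes on the series, read in a functional assay on U-87MG ATCC cells (Homo sapiens) for inhibition; on this read-out higher numbers stand for weaker inhibition and lower numbers for stronger inhibition. Compound 1 `COc1cc(/C=C/C(=O)c2cccc(NC(=O)c3cc(Cl)cc(Cl)c3)c2)ccc1O` gives > 50 ug/mL, which is a limit and not a number. Compound 1 therefore stands at the limit of > 50 ug/mL in this assay, at which 2 of the 3 values shown sit. Compound 3 `COc1cc(/C=C/C(=O)c2cccc(NC(=O)c3ccc(Cl)cc3Cl)c2)ccc1O` gives > 50 ug/mL, which is also a limit. Among the measured compounds shown here, compound 2 `COc1cc(/C=C/C(=O)c2cccc(N)c2)ccc1O`, with hydrogen on the nitrogen, gives 7.71 ug/mL, the only exact number so far.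

Compound 4 `COc1cc(/C=C/C(=O)c2cccc(NC(=O)c3ccc(Cl)c(Cl)c3)c2)ccc1O` is still to be measured. The change is 3,4-dichlorophenyl in place of 3,5-dichlorophenyl on a carbonyl carbon, with 3,4-dichlorophenyl in place of 3,5-dichlorophenyl on a carbonyl carbon.

For the measured compounds named here, two measured steps concern the carbonyl group on the nitrogen: an at least 6.4-fold lower number from compound 1 to compound 2 (0.81 log units; beyond the scatter) and an at least 6.4-fold higher number from compound 2 to compound 3 (0.81 log units; beyond the scatter). Both are beyond the scatter and point the same way, with weaker inhibition when the dichlorophenyl carbonyl group is present. The closest comparison, which also exchanges one dichlorophenyl pattern for another, is a step that the two limits leave unreadable from compound 1 to compound 3, so it gives no size. Compound 4 keeps the carbonyl group and both chlorines, and the expectation rests on compound 1 and compound 3 alone. No step beyond the scatter is expected in this assay, and the expected step is a step that the limit leaves unreadable from compound 1 to compound 4. The estimate for compound 4 is 60 ug/mL, with an expected range of 25 ug/mL to 120 ug/mL.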

Compound 4, half-maximal inhibitory concentration: 29.5 ug/mL
The estimate for compound 4 lay 2.0-fold (0.31 log units) above the measured number; the range from low to high includes it.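

Among the compounds shown here, compound 4 is the first of the dichlorophenyl amides to give an exact number in this assay, so the effect of acylating the nitrogen now has a measured size: a 3.8-fold higher number from compound 2 to compound 4 (0.58 log units; beyond the scatter) shows that inhibition remains weaker than with hydrogen on the nitrogen. Against the other two chlorine patterns there are only floors, an at least 1.6-fold lower number from compound 1 to compound 4 (0.22 log units; that floor lies within the scatter) and an at least 1.6-fold lower number from compound 3 to compound 4 (0.22 log units; that floor lies within the scatter), so 3,4-dichlorophenyl on the carbonyl carbon is not shown to differ beyond the scatter from 3,5-dichlorophenyl or 2,4-dichlorophenyl. Compound 1 and compound 3 remain limits and not numbers, so the three chlorine patterns cannot be put in order: the limit of > 50 ug/mL in this assay, at which 2 of the 4 values shown sit.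

The compounds shown leave open whether the weaker inhibition belongs to the amide itself or to the chlorines, which an acetyl group or an unsubstituted benzoyl group on the nitrogen would separate. They also leave open whether a single chlorine, or a carboxylic acid or an amine on that phenyl ring, would bring an amide closer to compound 2 at 7.71 ug/mL in this assay.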